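A Methoxypyridinyl Amide Returns to the Aryl Pattern

This account rests on a few compounds, and the source may have more. Where it says the series, first, only, none or still open, it means among the compounds named here.

Compound 1: `O=C(Nc1cccnc1)c1c(O)c2cccnc2n(-c2ccccc2)c1=O` — 30.3%
Compound 2: `O=C(NCc1ccncc1)c1c(O)c2cccnc2n(-c2ccccc2)c1=O` — 10%
Compound 3: `COc1ccc(NC(=O)c2c(O)c3cccnc3n(-c3ccccc3)c2=O)cn1` — not yet measured

In a functional assay on the whole organism for inhibition, with Rattus norvegicus as the target, read by paw edema, at a dose of 100 mg/kg by the oral route (a higher number here means more inhibition at the dose given (going by the name of the read-out), a lower number less inhibition), compound 1 gives 30.3%, while compound 2 gives 10%. Among the compounds with values here, compound 2 thus stands lowest of the two measured numbers, its only neighbour being compound 1, and the one measured step, a number 20.3 percentage points lower from compound 1 to compound 2 (beyond the scatter), lies beyond the scatter.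

The change to compound 3 is 6-methoxypyridin-3-yl in place of (pyridin-4-yl)methyl on an amide-type nitrogen. Within the data shown here, the single measured step bears on it in reverse: it went from a pyridinyl on the amide-type nitrogen to a methylene-linked pyridinyl and lost inhibition, whereas compound 3 brings a substituted pyridinyl back onto that nitrogen, as in compound 1. Among the measured compounds shown here, a rise beyond the scatter is therefore expected, roughly undoing the earlier loss, though the methoxy group has no measured precedent here.

Compound 3 is estimated to give 30%, within 12% to 50%. For compound 3 this estimate means an expected step of a number 20 percentage points higher from compound 2 to compound 3 (beyond the scatter).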

Compound 3, a percentage reported as inhibition, in the whole organism at one dose (the size of the read-out at that dose, not a potency): 13.1%
Compound 3: middle estimate off by 16.9 percentage points, on the high side, within the range that was stated.
By their numbers in this assay, from the lowest: compounds 2 and 3 (each within the scatter of the next); then compound 1.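

In this assay, bringing a substituted pyridinyl group back onto the amide-type nitrogen did not by itself restore inhibition, with a number 3.1 percentage points higher from compound 2 to compound 3 (within the scatter) as the step, so compound 2 and compound 3 cannot be told apart. The one-place change that separates compound 3 from compound 1 is methoxy in place of hydrogen on an aromatic carbon, and it gives a number 17.2 percentage points lower from compound 1 to compound 3 (beyond the scatter) as its step, the first sign that inhibition at this position depends on a substituent on the ring as well as on the linker to the nitrogen. No measured evidence here accounts for this loss.

The compounds shown leave open whether fluoro or an amine on that aromatic carbon would behave as methoxy does. They also leave open whether methoxy would matter on the methylene-linked ring of compound 2.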